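Swapping one basic side group for another in mouse distribution

A few compounds are considered here, and "the series" means these few. Any claim that something is new, unique, unknown or untested is made for them only; others in the source may bear on it.

Compound 2 `Cc1cn(-c2cc(NC(=O)c3ccc(C)c(Oc4ccccc4)c3)cc(N3CCN(C)CC3)c2)cn1` gives 9.26 L/kg in an ADME assay on the whole organism (Mus musculus, strain CD1) for pharmacokinetics, read by LC-MS, using cassette dosing, with a stated time of 24 h, at a dose of 0.4 mg/kg by the intravenous route (a higher number here means that more of the compound sits outside the plasma, a lower number that more of the compound stays in the plasma), the highest of the three numbers. Compound 1 `Cc1cn(-c2cc(NC(=O)c3ccc(C)c(Oc4ccccc4)c3)cc(C(F)(F)F)c2)cn1` gives 1.69 L/kg, and compound 3 `Cc1cn(-c2cc(NC(=O)c3ccc(C)c(C(=O)c4cccc(C#N)c4)c3)cc(N3CCN(C)CC3)c2)cn1` gives 4.7 L/kg. Compound 4 `Cc1cn(-c2cc(CN3CCC[C@H](N)C3)cc(NC(=O)c3ccc(C)c(Oc4ccccc4)c3)c2)cn1` differs from compound 2 by (3-aminopiperidin-1-yl)methyl in place of 4-methylpiperazin-1-yl on an aromatic carbon. Going by the values given here, the step of a 5.5-fold higher number from compound 1 to compound 2 (0.74 log units; beyond the scatter) is the only measured step that alters this aromatic carbon, and it was beyond the scatter; the step of a 2.0-fold lower number from compound 2 to compound 3 (0.29 log units; within the scatter) altered a different part of the molecule and stayed within the scatter. Among the compounds with values here, no measured step swaps one amine-bearing group for another, so for compound 4 only a step within the scatter is expected, a 1.1-fold higher number from compound 2 to compound 4 (0.03 log units; within the scatter). Compound 4 is therefore estimated at 10 L/kg, with a range from 4.5 L/kg to 22 L/kg.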

Compound 4, volume of distribution at steady state: 9.13 L/kg
Beside the measured number, compound 4's estimate is 1.1-fold (0.04 log units) above it; low and high end bracket the measured number.
By their numbers in this assay, from the lowest: compound 1; then compounds 3, 4 and 2 (each within the scatter of the next).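

In this assay, this aromatic carbon accepts a second amine-bearing group with no shift beyond the scatter (a 1.0-fold lower number from compound 2 to compound 4 (0.01 log units; within the scatter)), even though the entering group brings a hydrogen-bond donor and a defined stereocentre. Set against trifluoromethyl, the same group gives a step (a 5.4-fold higher number from compound 1 to compound 4 (0.73 log units; beyond the scatter)) beyond the scatter, so the earlier rise is not confined to 4-methylpiperazin-1-yl. No evidence is available to explain this result.

Still open, from the compounds shown here alone, is whether a carboxylic acid or a simple ether at this carbon would keep the number near the amine-bearing compounds. Going by these compounds, the opposite stereoisomer of the 3-aminopiperidine and a longer chain to its ring also remain untested here.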